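Swapping the Isocyanide Arm for a Methylsulfonyl Arm

The source may hold more compounds than are shown below. What is called first, only, known or untested is meant among the compounds shown, and "the series" means these compounds.

Of the compounds shown here, three have been tested in a functional assay on the whole organism with Rattus norvegicus as the target, with a stated time of 4 h, at a dose of 40 mg/kg by the intraperitoneal route (on this read-out higher numbers stand for more inhibition at the one dose given (going by the name of the read-out) and lower numbers for less inhibition), so far. Compound 1 `Cc1nc2c(CSc3ccccc3)cccn2c1C` gives 29% in this assay, and compound 2 `Cc1nc2c(C[S+]([O-])c3ccccc3)cccn2c1C` gives 42% in this assay. Compound 3 `[C-]#[N+]Cc1c(C)nc2c(OCc3ccccc3)cccn12` gives 96% in this assay, the highest of the three numbers: its nearest neighbour is compound 2, which lies lower by a gap beyond the usual scatter, and compound 1 lies lower still.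

Compound 4 `Cc1nc2c(OCc3ccccc3)cccn2c1CS(C)(=O)=O` is the next to be tested, and it differs from compound 3 in one place: a group of 4 heavy atoms (1 carbon, 2 oxygen, 1 sulfur; no ring) in place of a group of 2 heavy atoms (1 carbon, 1 nitrogen; no ring), on a saturated chain carbon bound to an aromatic carbon. For the measured compounds named here, no pair of measured compounds shows the effect of this exact change, so the step it brings in this assay cannot be read off the data already in hand; compound 3 alone sets the starting point.

Given that, compound 4 is expected to come in lower than compound 3, with a step of a number 41 percentage points lower from compound 3 to compound 4 (beyond the scatter), and an estimated value of 55%, most likely between 15% and 90%.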

Compound 4, a percentage reported as inhibition, in the whole organism at one dose (the size of the read-out at that dose, not a potency): 61%
For compound 4 the middle estimate is 6 percentage points below the measured one, and the stated range covers the measured number.
By their numbers in this assay, from the lowest: compound 1; then compound 2; then compound 4; then compound 3.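

For the compounds shown here, this is the first pair in the set that differs in one place, so the arm on the saturated chain carbon bound to an aromatic carbon can now be judged directly: in this assay, methylsulfonyl in place of the isocyanide gives a number 35 percentage points lower from compound 3 to compound 4 (beyond the scatter). What this carbon carries therefore matters for inhibition at the one dose given, yet compound 4 still gives 61%, so inhibition does not vanish once the isocyanide is gone. Nothing measured here bears on why the step occurs.

A single pair cannot show whether other arms at this carbon, such as an amine, a carboxylic acid or a longer chain, would keep more of the inhibition of compound 3. It also leaves open whether the same swap would bring a similar step on the core of compound 1.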